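Fluoro for hydrogen on the anilino ring of compound 3

A few compounds are considered here, and "the series" means these few. Any claim that something is new, unique, unknown or untested is made for them only; others in the source may bear on it.

Compound 1 `C#Cc1cccc(Nc2ncnn3ccc(COC[C@@H]4CNCCO4)c23)c1` — 4400 nM
Compound 2 `Cn1ncc2cc(Nc3ncnn4ccc(CN5CCC(N)CC5)c34)ccc21` — "not active" (no number reported) (no number reported)
Compound 3 `NC1CCN(Cc2ccn3ncnc(Nc4ccccc4)c23)CC1` — 140 nM

Of the compounds shown here, three sharing one core have been tested in a functional assay on NCI-N87 cells (Homo sapiens) for antiproliferative activity; a higher number here means a weaker inhibitor, a lower number a stronger inhibitor. Compound 3 gives 140 nM, the lowest of the two numbers on hand. Compound 1 gives 4400 nM, a far higher number, and the gap lies well beyond the scatter of the measurement. Compound 2 is reported as "not active" (no number reported) in this assay, without a number attached. For the measured compounds named here, none of the three pairs differs in a single place, so no step between measured compounds can be read from them.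

Compound 4 `NC1CCN(Cc2ccn3ncnc(Nc4cccc(F)c4)c23)CC1` is not yet measured. It differs from compound 3 in one place: fluoro in place of hydrogen on an aromatic carbon. The group enters on an aromatic carbon of a six-membered aromatic ring of carbon only, meta to a large group; the anilino of compound 3 becomes a (3-fluorophenyl)amino.

Going by the values given here, no measured pair here speaks directly to this exchange, so the expectation rests on the single change being small. The step from compound 3 to compound 4 is expected to be a 1.2-fold lower number from compound 3 to compound 4 (0.07 log units; within the scatter), that is, within the usual scatter. Compound 4 is therefore estimated at 120 nM in this assay, with a range from 40 nM to 400 nM.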

Compound 4, half-maximal inhibitory concentration: 280 nM
For compound 4 the middle estimate is 2.3-fold (0.37 log units) below the measured one; measured number inside the range.
By their numbers in this assay, from the lowest: compounds 3 and 4 (each within the scatter of the next); then compound 1.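

In this assay, for the compounds shown here, the exchange of hydrogen for fluoro on the anilino ring gives a 2.0-fold higher number from compound 3 to compound 4 (0.30 log units; within the scatter) and is the only step in this set that can be read between two measured compounds. Going by these compounds alone, it shows that on this aromatic carbon, meta to a large group, a single fluorine leaves the number within the scatter, so this change does not separate compound 4 from compound 3, whereas the earlier compounds differed in several places at once and could not isolate this position. Nothing on hand gives a cause for this step, which therefore stands as an observation without an explanation.

On these data alone, whether a chloro, a methoxy or a nitrile on the same carbon would also stay within the scatter remains open, as does the effect of fluoro on the other carbons of that ring. Since one small group at one position gives only one step, the compounds shown also leave open whether the anilino ring as a whole accepts change, and how a change there would combine with a different amine on the side chain.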